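Trifluoromethoxy for trifluoromethyl on compound 2

This account rests on a few compounds, and the source may have more. Where it says the series, first, only, none or still open, it means among the compounds named here.

In a functional assay on CWR22R cells (Homo sapiens) for antiproliferative activity, read by fluorescence and propidium iodide staining, with a stated time of 96 h (a lower number here means a stronger inhibitor, a higher number a weaker inhibitor), compound 1 (`CC(O)(CSc1cc(C(F)(F)F)cc(C(F)(F)F)c1)C(=O)Nc1ccc([N+](=O)[O-])cc1C(F)(F)F`) gives 2290 nM and compound 2 (`CC(O)(CSc1ccccc1C(F)(F)F)C(=O)Nc1cc(C(F)(F)F)cc(C(F)(F)F)c1`) gives 4370 nM on the same read-out. Among the measured compounds shown here, these two values lie within the scatter of each other, so compound 2 cannot be separated from compound 1 on the numbers so far. Compound 3 (`CC(O)(CSc1ccccc1OC(F)(F)F)C(=O)Nc1cc(C(F)(F)F)cc(C(F)(F)F)c1`) differs from compound 2 in one place: trifluoromethoxy in place of trifluoromethyl on an aromatic carbon with trifluoromethoxy in place of trifluoromethyl on an aromatic carbon. For the measured compounds named here, no measured pair covers this change, so no shift beyond the scatter is expected in this assay on present data. The estimated step of a 1.1-fold lower number from compound 2 to compound 3 (0.04 log units; within the scatter) stays small. Compound 3 is estimated at 4000 nM (range 1500 nM to 10000 nM).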

Compound 3, half-maximal inhibitory concentration: 2940 nM
Compound 3: middle estimate off by 1.4-fold (0.13 log units), on the high side, and the stated range covers the measured number.
By their numbers in this assay, from the lowest: compounds 1, 3 and 2 (each within the scatter of the next).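

In this assay, trifluoromethoxy in place of trifluoromethyl on an aromatic carbon, ortho to a large group, gives a 1.5-fold lower number from compound 2 to compound 3 (0.17 log units; within the scatter). Among the compounds shown here, this is the only one-place pair so far, and at this position the two groups cannot be told apart on this read-out. No supporting data bear on this result.

From the compounds shown here alone, whether an amine, a carboxylic acid or a plain hydrogen at this position would give a number beyond the scatter remains open. So does whether the same exchange behaves alike on another core.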